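The compounds below may be only part of what the source reports. "The series", "measured", "known", "first", "only" and "open" are said of these compounds alone.

Compound 1 `CC(C)Cc1cccc(Br)c1O[C@@H]1C[C@@H](CNC(=O)c2ccc(/C=C3\SC(=O)NC3=O)cc2)N(C(=O)c2ccccc2C(=O)c2ccc(F)cc2F)C1` gives 220 nM in a functional assay on THP-1 cells (Homo sapiens) for inhibition; a lower number here means a stronger inhibitor, a higher number a weaker inhibitor.
Compound 2 `CC(C)Cc1cccc(Br)c1O[C@@H]1C[C@@H](CNC(=O)c2ccc(/C=C3\SC(=O)NC3=O)cc2)N(C(=O)c2ccccc2C(=O)c2ccc(F)cc2)C1` gives 300 nM in this assay.
Compound 3 `O=C1NC(=O)/C(=C/c2ccc(C(=O)NC[C@@H]3C[C@@H](Oc4ccccc4-c4ccccc4)CN3C(=O)c3ccccc3C(=O)c3ccc(F)cc3)cc2)S1` gives 310 nM in this assay.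

Compound 2 holds the second highest of the three numbers, but compound 3, its nearest neighbour, and compound 1, its furthest, both sit within the scatter of it, so the three measured compounds do not separate from one another in this assay.

Compound 4 `CC(C)Cc1cccc(-c2ccccc2C(C)C)c1O[C@@H]1C[C@@H](CNC(=O)c2ccc(/C=C3\SC(=O)NC3=O)cc2)N(C(=O)c2ccccc2C(=O)c2ccc(F)cc2)C1` differs from compound 2 in one place: 2-isopropylphenyl in place of bromo on an aromatic carbon. Going by the values given here, two measured steps bear on this. The step of a 1.4-fold higher number from compound 1 to compound 2 (0.13 log units; within the scatter) concerns a fluoro elsewhere in the molecule and did not move the number beyond the scatter. More directly, the step of a 1.0-fold higher number from compound 2 to compound 3 (0.01 log units; within the scatter) swapped the whole 2-bromo-6-isobutylphenyl for 2-phenylphenyl, an exchange that also puts an aryl where compound 2 carries bromo, and the number stayed where it was. Nothing in the measured set shows a change at this part of the structure shifting the read-out.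

On that basis compound 4 is expected to stay within the scatter of compound 2, the expected step being a 1.1-fold higher number from compound 2 to compound 4 (0.03 log units; within the scatter). Compound 4 is estimated at 320 nM, with a range from 110 nM to 950 nM.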

Compound 4, half-maximal inhibitory concentration: 92 nM
For compound 4 the middle estimate is 3.5-fold (0.54 log units) above the measured one, and the stated range ends above it.
By their numbers in this assay, from the lowest: compound 4; then compounds 1, 2 and 3 (each within the scatter of the next).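

In this assay, putting 2-isopropylphenyl in place of bromo on this aromatic carbon gives a 3.3-fold lower number from compound 2 to compound 4 (0.51 log units; beyond the scatter), the first step among these compounds to lie beyond the scatter, so the read-out does respond to what this position carries. The earlier exchange of the whole 2-bromo-6-isobutylphenyl for 2-phenylphenyl gave a 1.0-fold higher number from compound 2 to compound 3 (0.01 log units; within the scatter), which is within the scatter, so that step did not predict this one: an aryl group entering this part of the structure is not neutral in every setting, and here, with the isobutyl group kept, the number falls. Nothing measured here accounts for the drop.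

The compounds shown leave open whether the step belongs to the added aromatic ring alone or also needs the isopropyl group, and what a plain phenyl, a 2-methoxyphenyl or a pyridine ring would give on this same carbon. Going by these compounds, it also remains open whether the step would carry over to the 2,4-difluorophenyl ketone of compound 1.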